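A few compounds are considered here, and "the series" means these few. Any claim that something is new, unique, unknown or untested is made for them only; others in the source may bear on it.

Measured compounds in a physicochemical assay for lipophilicity, at pH 7.4; a higher number here means a more lipophilic compound, a lower number a more polar compound:

compound 1, `O=C(Cc1nn(C2CCNC2)c(=O)c2ccccc12)Nc1ccc(OC(F)(F)F)c(Cl)c1`, gives 3.03
compound 2, `O=C(O)Cc1nn(Cc2cn3cc(OCC4CC4)c(Cl)cc3n2)c2ccccc2c1=O`, gives 2.13
compound 3, `COc1ccc(Cl)cc1NC(=O)Cc1nn(CC(=O)O)c(=O)c2ccccc12`, gives 1.9

Of these three, compound 1 has the highest number in this assay. Compound 2 lies nearest to it, a gap that is beyond the scatter of repeated measurements, and compound 3 lies furthest away, again beyond the scatter. Compound 1 is therefore the most lipophilic of the three measured compounds on these numbers.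

The next compound, compound 4, `O=C(Cc1nn(C2CC2)c(=O)c2ccccc12)Nc1ccc(OC(F)(F)F)c(Cl)c1`, has not yet been measured. It differs from compound 1 in one place:

cyclopropyl in place of pyrrolidin-3-yl on an aromatic nitrogen

The group that leaves carries one hydrogen-bond donor and one hydrogen-bond acceptor; the group that enters carries neither, and it is smaller by two heavy atoms. For the measured compounds named here, no pair of measured compounds here shows exactly this change, so the size of the step can only be estimated from what the groups themselves bring and take away. The expectation is a rise in this assay, a step of a number 1.17 log units higher from compound 1 to compound 4 (beyond the scatter) from compound 1 to compound 4, clearly beyond the scatter. On that basis compound 4 is estimated at 4.2, with a range from 3.6 to 4.9.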

Compound 4, distribution coefficient: 5.43
Estimate against measurement, compound 4: 1.23 log units below; the measured number lies above the stated range.
By their numbers in this assay, from the lowest: compounds 3 and 2 (each within the scatter of the next); then compound 1; then compound 4.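

In this assay, for the compounds shown here, putting cyclopropyl in place of pyrrolidin-3-yl on the aromatic nitrogen gives a number 2.40 log units higher from compound 1 to compound 4 (beyond the scatter), a large step and the first reading of a change made in one place only. It shows that, with the rest of the molecule left as it is, the group on this nitrogen can by itself move the number a long way. The step replaces a five-membered ring containing a nitrogen with a three-membered ring of carbon only, so ring size and the presence of that nitrogen change together, and no measurement here shows what lies behind the size of the step.

Which of these two differences matters more stays open, and a cyclopentyl group on the same nitrogen, which would keep the five-membered ring but lose the nitrogen, would begin to separate them. Also open, from the compounds shown here alone, is whether an open chain such as n-butyl at this position would land near compound 4 at 5.43, or whether that high number is particular to the cyclopropyl ring.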